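The source may report more compounds than this note shows. Statements on the series, on what has been measured and on what is new or still open speak of the compounds shown alone.

Measured so far in a functional assay on MCF7 cells (Homo sapiens) for inhibition, read by MTT assay, with a stated time of 72 h; a lower number here means a stronger inhibitor, a higher number a weaker inhibitor:

compound 1 `CN(C(=O)NC(=O)c1ccc(F)c(F)c1)c1nc(C(F)(F)F)c(C(=O)N/N=C/c2cc(C(F)(F)F)cc(C(F)(F)F)c2)s1` gives 2.61 ug/mL
compound 2 `CN(C(=O)NC(=O)c1ccc(C(F)(F)F)cc1)c1nc(C(F)(F)F)c(C(=O)N/N=C/c2cccc(C(F)(F)F)c2)s1` gives 8.95 ug/mL
compound 3 `CN(C(=O)NC(=O)c1ccc(C(F)(F)F)cc1)c1nc(C(F)(F)F)c(C(=O)N/N=C/c2cc(C(F)(F)F)cc(C(F)(F)F)c2)s1` gives 7.37 ug/mL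

Compound 3 and compound 1 share a core and differ only in the group on the carbonyl carbon: 3,4-difluorophenyl in place of 4-(trifluoromethyl)phenyl on a carbonyl carbon. That change produced a 2.8-fold lower number from compound 3 to compound 1 (0.45 log units; beyond the scatter), a step beyond the scatter. Compound 2 and compound 3 differ in their cores by hydrogen in place of trifluoromethyl on an aromatic carbon, a change that gave a 1.2-fold lower number from compound 2 to compound 3 (0.08 log units; within the scatter), so the two values lie within the scatter of each other and no order between them is read.

Compound 4 `CN(C(=O)NC(=O)c1ccc(F)c(F)c1)c1nc(C(F)(F)F)c(C(=O)N/N=C/c2cccc(C(F)(F)F)c2)s1` has not yet been measured in this assay. It stands to compound 2 as compound 1 stands to compound 3: 3,4-difluorophenyl in place of 4-(trifluoromethyl)phenyl on a carbonyl carbon. The place of the change is described in the same words in both pairs, so this is the same change on a core that differs as described above. The step from compound 2 to compound 4 is expected to be a 2.8-fold lower number from compound 2 to compound 4 (0.45 log units; beyond the scatter), an expectation that rests on the same change having given a 2.8-fold lower number from compound 3 to compound 1 (0.45 log units; beyond the scatter). Compound 4 is therefore estimated at 3.2 ug/mL, expected to fall between 1.6 ug/mL and 6.5 ug/mL.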

Compound 4, half-maximal inhibitory concentration: 4.15 ug/mL
Estimate against measurement, compound 4: 1.3-fold (0.11 log units) below; the range from low to high includes it.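

In this assay, the change from 4-(trifluoromethyl)phenyl to 3,4-difluorophenyl on the carbonyl carbon carries over to the second core, with a 2.2-fold lower number from compound 2 to compound 4 (0.33 log units; beyond the scatter), and its size agrees on both cores: the same change on two cores in this assay, a 2.8-fold lower number (0.45 log units; beyond the scatter) from compound 3 to compound 1 and a 2.2-fold lower number (0.33 log units; beyond the scatter) from compound 2 to compound 4, 1.3-fold (0.12 log units) apart, within the scatter of two such steps

The other change, hydrogen in place of trifluoromethyl on an aromatic carbon, gives a 1.6-fold higher number from compound 1 to compound 4 (0.20 log units; within the scatter), so compound 1 and compound 4 do not separate, and this holds on both backgrounds: the same change on two cores in this assay, a 1.2-fold lower number (0.08 log units; within the scatter) from compound 2 to compound 3 and a 1.6-fold lower number (0.20 log units; within the scatter) from compound 4 to compound 1, 1.3-fold (0.12 log units) apart, within the scatter of two such steps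

This shows transfer only between two cores that differ in a single trifluoromethyl, for one pair of groups in one cell assay; it does not show that the step holds on more distant cores, and it gives no reason for the step.

Every group shown on the carbonyl carbon is a fluorinated phenyl, so the compounds leave open what a methoxy group, an amine or a carboxylic acid on that phenyl ring would do. Also open, as far as these compounds go, is whether a plain alkyl chain could stand in place of the ring.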